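Capping the hydroxyl: compound 2 to compound 3

The source may report more compounds than this note shows. Statements on the series, on what has been measured and on what is new or still open speak of the compounds shown alone.

Of the compounds shown here, two of a shared core have been measured so far. Compound 1 `N#Cc1cnc(NCc2cnccc2C(F)(F)F)cc1NC[C@H]1C[C@H](O)C1` gives 700 nM in an assay on isolated protein for inhibition of protein kinase C theta type (Homo sapiens), read by TR-FRET, with a stated time of 2 h (on this read-out higher numbers stand for weaker inhibition and lower numbers for stronger inhibition), and compound 2 `N#Cc1cnc(NCc2cnccc2C(F)(F)F)cc1N[C@H]1CC[C@H](O)CC1` gives 350 nM in this assay. Among the measured compounds shown here, the only measured step, a 2.0-fold lower number from compound 1 to compound 2 (0.30 log units; within the scatter), exchanges one ring-bearing group for another and lies within the scatter. Compound 2 therefore holds the lower of the two numbers, but its gap to compound 1 is too small to rank the two.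

Compound 3 `CO[C@H]1CC[C@@H](Nc2cc(NCc3cnccc3C(F)(F)F)ncc2C#N)CC1` differs from compound 2 in one place: 4-methoxycyclohexyl in place of 4-hydroxycyclohexyl on a nitrogen on an aromatic ring. The change keeps the ring and its two defined stereocentres and removes the one hydrogen-bond donor, leaving the single acceptor. For the measured compounds named here, no measured step touches this particular exchange; the step from compound 1 to compound 2 alters the ring itself, not the oxygen group on it, so it offers no direct guide.

Going by the values given here, with no measured precedent, the expectation for compound 3 in this assay is a step of a 1.7-fold higher number from compound 2 to compound 3 (0.23 log units; within the scatter), which stays inside the scatter. Compound 3 is therefore estimated at 600 nM, with a range from 200 nM to 2000 nM.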

Compound 3, half-maximal inhibitory concentration: 58 nM
Compound 3: the middle estimate sits 10-fold (1.01 log units) above what was measured; measured number below the stated range.
By their numbers in this assay, from the lowest: compound 3; then compounds 2 and 1 (each within the scatter of the next).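

In this assay, among the compounds shown here, replacing 4-hydroxycyclohexyl with 4-methoxycyclohexyl gives a 6.0-fold lower number from compound 2 to compound 3 (0.78 log units; beyond the scatter), the first step at this position to fall beyond the scatter, so this nitrogen substituent can clearly move the number even when the ring and its two defined stereocentres stay the same. The step that changes the ring and keeps a free hydroxyl, a 2.0-fold lower number from compound 1 to compound 2 (0.30 log units; within the scatter), stays within the scatter, whereas the step that changes both the ring and the oxygen group, a 12-fold lower number from compound 1 to compound 3 (1.08 log units; beyond the scatter), is large, so among these three compounds a clear shift appears only with the methoxy group. Nothing else measured here bears on why the methoxy compound gives the lower number.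

The loss of the hydroxyl hydrogen and the gain of one carbon arrive in a single change, and these compounds cannot separate the two. On these data alone, how a plain cyclohexyl, a 4-ethoxycyclohexyl or a 4-aminocyclohexyl would read at this position stays open, as does whether capping the hydroxyl of the (3-hydroxycyclobutyl)methyl group would act in the same way.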